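Compound 3 Against the Two Measured Esters

This account rests on a few compounds, and the source may have more. Where it says the series, first, only, none or still open, it means among the compounds named here.

Compound 1 `CC(C)=CC[C@@H](OC(=O)CCO)C1=CC(=O)c2c(O)ccc(O)c2C1=O` gives 55300 nM
Compound 2 `CC(C)=CC[C@@H](OC(=O)C1CCCCO1)C1=CC(=O)c2c(O)ccc(O)c2C1=O` gives 24700 nM

In a functional assay on DU-145 cells (Homo sapiens) for cytotoxicity, read by MTT assay (a lower number here means a stronger inhibitor, a higher number a weaker inhibitor), compound 2 holds the lower of the two numbers, 24700 nM, while compound 1 stands higher at 55300 nM. Compound 3 `CCC(O)(CC)CC(=O)O[C@H](CC=C(C)C)C1=CC(=O)c2c(O)ccc(O)c2C1=O` has not yet been measured. It differs from compound 2 by a single change 2-ethyl-2-hydroxybutyl in place of oxan-2-yl on a carbonyl carbon.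

For the measured compounds named here, only one measured step bears on this change: a 2.2-fold lower number from compound 1 to compound 2 (0.35 log units; beyond the scatter). That modest step came with oxan-2-yl in place of 2-hydroxyethyl on a carbonyl carbon. Compound 3 gives up the same oxan-2-yl and, like compound 1 at 55300 nM, carries an open chain with a hydroxy group. A small partial return towards the higher number is therefore expected, though one step is thin evidence and the new chain is larger. The expected change in this assay is a 1.3-fold higher number from compound 2 to compound 3 (0.13 log units; within the scatter), no larger than the modest measured step. For compound 3 the estimated value is 33000 nM, with an expected range from 14000 nM to 75000 nM.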

Compound 3, half-maximal inhibitory concentration: 67000 nM
Beside the measured number, compound 3's estimate is 2.0-fold (0.31 log units) below it, and the stated range covers the measured number.
By their numbers in this assay, from the lowest: compound 2; then compounds 1 and 3 (each within the scatter of the next).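

In this assay, the open 2-ethyl-2-hydroxybutyl chain does not keep the level of the oxan-2-yl ring: the measured change is a 2.7-fold higher number from compound 2 to compound 3 (0.43 log units; beyond the scatter) in this series, which leaves compound 2 the strongest of the three esters. The larger open chain also gives no clear separation from the shorter one, with a 1.2-fold higher number from compound 1 to compound 3 (0.08 log units; within the scatter) between these two hydroxy-bearing esters, so at this position, on the carbonyl carbon, lengthening and branching the chain shows no measurable gain over compound 1. No evidence is available to explain the advantage of compound 2 over either open-chain ester.

The swap from oxan-2-yl to 2-ethyl-2-hydroxybutyl removes one six-membered non-aromatic ring and brings in 1 hydrogen-bond donor together, so these three compounds cannot show which of the two differences goes with the higher number. A cyclohexyl ring in place of oxan-2-yl, or a plain pentyl chain carrying no hydroxy group, would be needed to pull those two differences apart, and an amine on the chain remains an open question as well.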